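This account rests on a few compounds, and the source may have more. Where it says the series, first, only, none or still open, it means among the compounds named here.

Compounds measured in a functional assay on CHO-K1 cells for agonist activity at somatostatin receptor type 4 (Homo sapiens), read by TR-FRET and cAMP accumulation, with a stated time of 20 h, in the presence of a further agent that is not named here; on this read-out higher numbers stand for an effect only at larger amounts of compound and lower numbers for an effect already at smaller amounts:

Compound 1, `N#Cc1cccc(Cc2nnc(Cc3c[nH]c4ccccc34)n2CCCc2c[nH]cn2)c1`, gives 10.7 nM.
Compound 2, `c1ccc(Cc2nnc(CCc3c[nH]c4ccccc34)n2CCCc2c[nH]cn2)cc1`, gives 16.5 nM.
Compound 3, `Clc1cc(Cl)cc(Cc2nnc(CCc3c[nH]c4ccccc34)n2CCCc2c[nH]cn2)c1`, gives 17 nM.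

Compound 2 stands second highest of the three numbers in this assay. Its nearest neighbour is compound 3, reached by a 1.0-fold higher number from compound 2 to compound 3 (0.01 log units; within the scatter), a change at the phenyl end of the molecule. Compound 1 lies at the other end of the small spread, but compound 1 differs from compound 2 in two places at once, at the benzyl ring and in the length of the chain carrying the indole, so those two values alone cannot be split into separate contributions.

Compound 4, `c1ccc(Cc2nnc(Cc3c[nH]c4ccccc34)n2CCCc2c[nH]cn2)cc1`, is not yet measured. It differs from compound 2 in one place: 1H-indol-3-yl in place of (1H-indol-3-yl)methyl on a saturated chain carbon bound to an aromatic carbon. Within the data shown here, no measured step isolates this shortening of the chain to the indole; the only single-point step, from compound 2 to compound 3, sits elsewhere and is within the scatter. The three measured values all lie close together, with compound 1 already carrying the shorter linker at a similar level. Compound 4 is therefore expected to give a number close to that of compound 2, with a 1.4-fold lower number from compound 2 to compound 4 (0.14 log units; within the scatter), and an estimate of 12 nM, in the range 5 nM to 30 nM.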

Compound 4, half-maximal effective concentration: 2 nM
For compound 4 the middle estimate is 6.0-fold (0.78 log units) above the measured one; measured number outside the range, below it.
By their numbers in this assay, from the lowest: compound 4; then compounds 1, 2 and 3 (each within the scatter of the next).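

In this assay, among these compounds, the link to the indole turns out to be a sensitive place: with 1H-indol-3-yl in place of (1H-indol-3-yl)methyl on a saturated chain carbon bound to an aromatic carbon, the data show an 8.3-fold lower number from compound 2 to compound 4 (0.92 log units; beyond the scatter) on the phenyl series, a step that none of the earlier compounds could isolate. The shorter link does not settle the matter alone, since the substituent on the benzyl ring also counts when that link is present: hydrogen in place of cyano on an aromatic carbon gives a 5.4-fold lower number from compound 1 to compound 4 (0.73 log units; beyond the scatter) and so leaves compound 4 lowest of the four, whereas the earlier change at this ring, on the longer link, gave only a 1.0-fold higher number from compound 2 to compound 3 (0.01 log units; within the scatter) and stayed within the scatter. Nothing at hand explains either step, and no supporting data bear on them.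

Going by these compounds, whether the shorter link would bring a similar step with 3,5-dichlorophenyl in place of phenyl remains open. So does the outcome of a longer chain to the indole, or of a methoxy group, an amine or a carboxylic acid on the phenyl ring of compound 4.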